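The source may report more compounds than this note shows. Statements on the series, on what has been measured and on what is new or still open speak of the compounds shown alone.

Measured compounds:
- Compound 1 `CCCCCCSc1ccn([C@@H]2O[C@H](COP(=O)(O)OP(=O)(O)OP(=O)(O)O)[C@@H](O)[C@H]2O)c(=O)n1` gives 840 nM in a functional assay on cells for agonist activity at P2Y purinoceptor 2 (Homo sapiens), read by inositol phosphate accumulation, with a stated time of 90 min; on this read-out lower numbers stand for an effect already at smaller amounts and higher numbers for an effect only at larger amounts of compound.
- Compound 2 `CN(C)c1ccn([C@@H]2O[C@H](COP(=O)(O)OP(=O)(O)OP(=O)(O)O)[C@@H](O)[C@H]2O)c(=O)n1` gives 29800 nM in this assay.

On these two numbers compound 2 stands highest, with compound 1 at the lower end. Within the data shown here, the only measured step runs between them: a 35-fold higher number from compound 1 to compound 2 (1.55 log units; beyond the scatter). The question here is compound 3 `CCCCCCNc1ccn([C@@H]2O[C@H](COP(=O)(O)OP(=O)(O)OP(=O)(O)O)[C@@H](O)[C@H]2O)c(=O)n1`, which differs from compound 2 in one place: hexylamino in place of dimethylamino on an aromatic carbon. The step from compound 1 to compound 2 bears on this change, since it removed a hexyl chain from that same aromatic carbon and the hexylamino group of compound 3 brings a hexyl chain back, although attached through nitrogen rather than sulfur. Among the measured compounds shown here, no measured pair separates the effect of the hexyl chain from that of the sulfur-to-nitrogen exchange, so the comparison is only partial. Given that compound 2 is so far from compound 1 in this assay, compound 3 is expected to move back toward compound 1 by a large step, a 15-fold lower number from compound 2 to compound 3 (1.17 log units; beyond the scatter). The estimate for compound 3 in this assay is 2000 nM, with a range from 500 nM to 10000 nM.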

Compound 3, half-maximal effective concentration: 26300 nM
Compound 3: middle estimate off by 13-fold (1.12 log units), on the low side; measured number outside the range, above it.
By their numbers in this assay, from the lowest: compound 1; then compounds 3 and 2 (each within the scatter of the next).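

In this assay, bringing a hexyl chain back on nitrogen does not recover the low number of compound 1: the change to hexylamino from dimethylamino gives a 1.1-fold lower number from compound 2 to compound 3 (0.05 log units; within the scatter) and so makes no readable difference at this aromatic carbon. With the hexyl chain held constant, exchanging hexylsulfanyl for hexylamino gives a 31-fold higher number from compound 1 to compound 3 (1.50 log units; beyond the scatter), a step about as large as the earlier 35-fold higher number from compound 1 to compound 2 (1.55 log units; beyond the scatter), so among these three compounds the large difference goes with the loss of the sulfur link, and chain length on nitrogen does not alter the number. Nothing available explains why the sulfur-linked and nitrogen-linked groups differ in this way.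

The compounds shown leave open whether the hexyl chain matters at all when it is attached through sulfur, since a shorter group such as methylsulfanyl would be needed to test this. They also leave open whether a hexyl chain attached through oxygen, as hexyloxy, would fall with compound 1 or with the two nitrogen-linked compounds.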